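A few compounds are considered here, and "the series" means these few. Any claim that something is new, unique, unknown or untested is made for them only; others in the source may bear on it.

Measured in an ADME assay on a cell-free system (plasma), read by LC-MS, with a stated time of 1 h, tested at 5 uM; on this read-out higher numbers stand for a more stable compound and lower numbers for a less stable compound:
- compound 1 `O=C(O)c1ccc(NCc2c(-c3c(Cl)cccc3C(F)(F)F)noc2-c2ccco2)cc1`: 86.5%
- compound 2 `O=C(O)c1ccc(NC(=O)c2c(-c3c(Cl)cccc3C(F)(F)F)noc2-c2ccccc2)cc1`: 99.9%

Compound 1 holds the lower of the two numbers, and compound 2 stands higher by a margin beyond the usual scatter. Not yet measured is compound 3 `O=C(O)c1ccc(NCc2c(-c3c(Cl)cccc3C(F)(F)F)noc2-c2cc[nH]c2)cc1`. It departs from compound 1 at one place, on an aromatic carbon next to the ring oxygen: 1H-pyrrol-3-yl in place of furan-2-yl on an aromatic carbon. In words, 1H-pyrrol-3-yl takes the place of furan-2-yl. For the measured compounds named here, no measured pair shows this change, so the data give no direct guide to its size. The expectation therefore starts from compound 1 at 86.5% and assumes no shift beyond the scatter in this assay, in either direction. The estimated step, a number 1.5 percentage points lower from compound 1 to compound 3 (within the scatter), is expected to stay within that scatter. For compound 3 the expected value is 85%, with an estimated range from 70% to 98%.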

Compound 3, percent of the compound remaining in the plasma assay: 85.9%
The estimate for compound 3 lay 0.9 percentage points below the measured number; low and high end bracket the measured number.
By their numbers in the plasma assay, from the lowest: compounds 3 and 1 (each within the scatter of the next); then compound 2.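

For the compounds shown here, with 1H-pyrrol-3-yl in place of furan-2-yl, on an aromatic carbon next to the ring oxygen, the plasma assay gives a number 0.6 percentage points lower from compound 1 to compound 3 (within the scatter) as the first one-place step; there compound 1 gives 86.5% and compound 3 gives 85.9%. In a physicochemical assay for solubility, read by spectrophotometry, measured as kinetic solubility, with a stated time of 90 min, at pH 7.4, tested at 500 uM (on this read-out higher numbers stand for higher solubility and lower numbers for lower solubility), the same change gives a 1.0-fold higher number from compound 1 to compound 3 (0.02 log units; within the scatter) at this position. In the physicochemical assay compound 1 gives 392000 nM and compound 3 gives 411000 nM. A hydrogen-bond acceptor in the leaving ring and a hydrogen-bond donor in the entering ring thus coexist with matching read-outs in both assays, though no supporting measurement speaks to why the two compounds read alike.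

From the compounds shown here alone, whether this position accepts an amine, a carboxylic acid or a longer chain in place of the five-membered aromatic ring remains open. Also open, going by these compounds, is whether 1H-pyrrol-2-yl or a five-membered aromatic ring with two nitrogens would read the same here.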